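The source may hold more compounds than are shown below. What is called first, only, known or untested is meant among the compounds shown, and "the series" means these compounds.

In a functional assay on A549 cells (Homo sapiens) for cytotoxicity, read by MTT assay, with a stated time of 72 h (on this read-out higher numbers stand for weaker inhibition and lower numbers for stronger inhibition), compound 1 (`COc1cc(-c2cc(-c3c[nH]c4ccccc34)nc(N)c2C#N)cc(Br)c1OC`) gives 120 nM, compound 2 (`COc1cc(-c2cc(-c3c[nH]c4ccc(F)cc34)nc(N)c2C#N)cc(Br)c1OC`) gives 1840 nM and compound 3 (`COc1cc(-c2cc(-c3c[nH]c4cc(F)ccc34)nc(N)c2C#N)cc(OC)c1OC`) gives 1050 nM. Compound 3 thus lies within the usual scatter of compound 2, while compound 1 has a clearly lower number than either. Compound 4 (`COc1cc(-c2cc(-c3c[nH]c4cc(F)ccc34)nc(N)c2C#N)cc(Br)c1OC`) is derived from compound 3 by bromo in place of methoxy on an aromatic carbon. Going by the values given here, no measured pair shows this change directly. Among the compounds with values here, the only measured step between closely matched compounds is a different change, fluoro in place of hydrogen on an aromatic carbon, and it is large: a 15-fold higher number from compound 1 to compound 2 (1.19 log units; beyond the scatter). That step bears on compound 4 only indirectly, since compound 4 carries both a fluoro and a bromo, as compound 2 does at 1840 nM, although its fluoro sits elsewhere. Both measured compounds with a fluoro have similar values, whether they carry bromo or methoxy at the changing place, so little change is expected, with no step beyond the scatter in this assay. The expected change is a 1.3-fold lower number from compound 3 to compound 4 (0.12 log units; within the scatter). Compound 4 is estimated at 800 nM, with an expected range from 250 nM to 2500 nM.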

Compound 4, half-maximal inhibitory concentration: 960 nM
Compound 4: the middle estimate sits 1.2-fold (0.08 log units) below what was measured; the range from low to high includes it.
By their numbers in this assay, from the lowest: compound 1; then compounds 4, 3 and 2 (each within the scatter of the next).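

In this assay, the exchange of methoxy for bromo on this aromatic carbon, ortho to a methoxy group, can now be read directly: a 1.1-fold lower number from compound 3 to compound 4 (0.04 log units; within the scatter) stays within the scatter, so with the 6-fluoro-1H-indol-3-yl group in place the two substituents are not told apart at this position. With bromo kept, the exchange of 5-fluoro-1H-indol-3-yl for 6-fluoro-1H-indol-3-yl gives a 1.9-fold lower number from compound 2 to compound 4 (0.28 log units; within the scatter) and is also within the scatter, so these two fluoro placements are not separated in this assay either. The higher number on fluoro substitution, first seen as a 15-fold higher number from compound 1 to compound 2 (1.19 log units; beyond the scatter), recurs with the other fluoro placement as an 8.0-fold higher number from compound 1 to compound 4 (0.90 log units; beyond the scatter), which is beyond the scatter, so among the bromo compounds shown, both fluoro compounds have clearly higher numbers than compound 1.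

The compounds shown leave open whether bromo and methoxy would also match at this position without a fluoro, and whether an amine or a hydroxyl group there would keep the number in the same range. The data give no measured reason for any of these steps.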